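Methyl to Bromo Swap Across Two Cores

The compounds below may be only part of what the source reports. "The series", "measured", "known", "first", "only" and "open" are said of these compounds alone.

Measured compounds in a functional assay on HBL-100 cells (Homo sapiens) for inhibition, read by sulforhodamine B assay, with a stated time of 48 h; on this read-out higher numbers stand for weaker inhibition of growth and lower numbers for stronger inhibition of growth:
compound 1 `COC(=O)[C@@]1(C)CCC=C2[C@@H]1CC[C@@H](C)[C@]2(C)Cc1c(C)[nH]c2ccc(C)cc12` gives 25000 nM
compound 2 `COC(=O)[C@@]1(C)CCC=C2[C@@H]1CC[C@@H](C)[C@]2(C)Cc1c(C)[nH]c2ccc(Br)cc12` gives 15000 nM
compound 3 `COC(=O)[C@@]1(C)CC[C@@H]2C3=C1CC[C@@H](C)[C@]3(C)Cc1c2[nH]c2ccc(C)cc12` gives 11000 nM

Compound 1 and compound 2 share one core and differ in a single place: bromo in place of methyl on an aromatic carbon. That change produced a 1.7-fold lower number from compound 1 to compound 2 (0.22 log units; within the scatter). Compound 3 has a different core; the difference between the core of compound 1 and the core of compound 3 is not broken down here. In this assay compound 3 gives a lower number than compound 1, a gap beyond the scatter, whereas compound 3 and compound 2 lie within the scatter of each other.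

Compound 4 `COC(=O)[C@@]1(C)CC[C@@H]2C3=C1CC[C@@H](C)[C@]3(C)Cc1c2[nH]c2ccc(Br)cc12` is the unmeasured partner of compound 3: bromo in place of methyl on an aromatic carbon. Its place matches that in compound 2 except that the ring is part of a fused or bridged system of five rings rather than two, so this is the same kind of change, not the same change.

Among the compounds with values here, only one earlier instance of this swap is in hand, a 1.7-fold lower number from compound 1 to compound 2 (0.22 log units; within the scatter), and it lies within the scatter. From compound 3 to compound 4 a step of about a 1.6-fold lower number from compound 3 to compound 4 (0.20 log units; within the scatter) is expected in this assay, on that basis alone. Compound 4 is therefore estimated at 7000 nM, between 3500 nM and 14000 nM.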

Compound 4, concentration for 50% growth inhibition: 16000 nM
The estimate for compound 4 lay 2.3-fold (0.36 log units) below the measured number; measured number outside the range, above it.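

In this assay, bromo in place of methyl on the core of compound 3 gives a 1.5-fold higher number from compound 3 to compound 4 (0.16 log units; within the scatter), a step that cannot be told apart from no change. Set beside the earlier step, this one does not differ from it by more than repeated measurement allows, so the opposite directions of the two steps carry no weight: the same change on two cores in this assay, a 1.7-fold lower number (0.22 log units; within the scatter) from compound 1 to compound 2 and a 1.5-fold higher number (0.16 log units; within the scatter) from compound 3 to compound 4, 2.4-fold (0.38 log units) apart, within the scatter of two such steps. This shows that the change stays within the scatter on both cores, but it does not show that its effect is the same on both or that it would stay small on any other core; two small steps fix neither a size nor a direction.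

The compounds shown leave open whether a different group on this aromatic carbon, such as a methoxy group or a nitrile, would move the number beyond the scatter on either core. Also open, going by these compounds, is how either core would respond if a carboxylic acid or an amide took the place of the methyl ester.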